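The source may report more compounds than this note shows. Statements on the series, on what has been measured and on what is new or still open speak of the compounds shown alone.

Compound 2 `CNC(=O)c1cc(Oc2ccc(NC(=O)c3cc(-c4ccc(F)cc4)ncn3)cc2)ccn1` is the reference point of this step. In a functional assay on A549 cells (Homo sapiens) for cytotoxicity, read by MTT assay, with a stated time of 72 h (a lower number here means a stronger inhibitor, a higher number a weaker inhibitor), compound 2 is reported only as a limit of the assay, > 100000 nM, and not as a number. The two compounds that differ from it in one place stand no better. Compound 1 `CNC(=O)c1cc(Oc2ccc(NC(=O)c3cc(-c4ccc(F)cc4)ncn3)cc2F)ccn1` gives in this assay a limit as well, > 100000 nM. Compound 3 `CNC(=O)c1cc(Oc2ccc(NC(=O)c3cc(-c4ccc(Cl)cc4)ncn3)cc2F)ccn1` likewise sits in this assay at a limit, > 100000 nM. The two measured steps, a step that the two limits leave unreadable from compound 1 to compound 2 and a step that the two limits leave unreadable from compound 1 to compound 3, cannot be read in size or direction because the limit of > 100000 nM in this assay, at which 3 of the 3 values shown sit, leaves both ends of each step unresolved.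

Compound 4 `CNC(=O)c1cc(Oc2ccc(NC(=O)c3cc(-c4ccc(OC)cc4)ncn3)cc2)ccn1` differs from compound 2 by methoxy in place of fluoro on an aromatic carbon. Among the measured compounds shown here, no measured step bears readably on this change; all that can be said is that every value so far in this assay sits at the limit.

Compound 4 is therefore expected to remain at or near the limit, estimated at 100000 nM with a range from 30000 nM to 300000 nM, most likely reported again as a limit rather than a number. The expected step from compound 2 to compound 4 is a number no higher from compound 2 to compound 4 (the limit leaves the size open), meaning no readable change.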

Compound 4, half-maximal inhibitory concentration: 13500 nM
Estimate against measurement, compound 4: 7.4-fold (0.87 log units) above; measured number below the stated range.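

In this assay, among the compounds shown here, the change from 4-fluorophenyl to 4-methoxyphenyl gives the only readable step: an at least 7.4-fold lower number from compound 2 to compound 4 (0.86 log units; beyond the scatter). For the compounds shown here, compound 4 shows that a number can be obtained and that the place para to a large group responds to a change of substituent, which the earlier compounds could not show: the limit of > 100000 nM in this assay, at which 3 of the 4 values shown sit. Compound 2 is a limit, > 100000 nM, and the step therefore gives a bound and not a size.

From the compounds shown here alone, with a single readable change at this place, it remains open whether the drop in the number belongs to methoxy alone or extends to groups such as ethoxy, hydroxy or dimethylamino. Also open, going by these compounds, is whether methoxy has the same effect on the core of compound 1, which carries a further fluoro.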